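The source may report more compounds than this note shows. Statements on the series, on what has been measured and on what is new or still open speak of the compounds shown alone.

In a functional assay on SK-OV-3 cells (Homo sapiens) for cytotoxicity, read by MTT assay, with a stated time of 48 h (a higher number here means a weaker inhibitor, a lower number a stronger inhibitor), compound 1 `Clc1ccnc2cc(OCc3ccccc3)ccc12` gives 5170 nM and compound 2 `Fc1ccc(COc2ccc3c(Cl)ccnc3c2)cc1` gives 2780 nM, so the two stand within the scatter of each other. In compound 3 `C=CCOc1ccc2c(Cl)ccnc2c1`, vinyl takes the place of phenyl on a saturated chain carbon bound to an oxygen on an aromatic ring: vinyl in place of phenyl on a saturated chain carbon bound to an oxygen on an aromatic ring. Among the compounds with values here, the only measured step, a 1.9-fold lower number from compound 1 to compound 2 (0.27 log units; within the scatter), puts fluoro in place of hydrogen on that phenyl and keeps the ring, so it offers only weak guidance for removing it. A modest move towards a higher number is expected, a 1.7-fold higher number from compound 1 to compound 3 (0.24 log units; within the scatter). For compound 3 the estimated value is 9000 nM, with an expected range from 3500 nM to 25000 nM.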

Compound 3, half-maximal inhibitory concentration: 4030 nM
Compound 3: middle estimate off by 2.2-fold (0.35 log units), on the high side; the measured number falls inside the stated range.
By their numbers in this assay, from the lowest: compounds 2, 3 and 1 (each within the scatter of the next).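

In this assay, replacing the phenyl with the much smaller vinyl removes the whole aromatic ring from this place and gives a 1.3-fold lower number from compound 1 to compound 3 (0.11 log units; within the scatter). On this saturated chain carbon, then, compound 3 shows that the ring can go without a step beyond the scatter, something the earlier fluoro step, which kept the ring, could not show. Nothing at hand gives a reason for this result. As far as these compounds go, whether an amine, a carboxylic acid or a longer chain at this place would also stay within the scatter remains open.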